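The source may report more compounds than this note shows. Statements on the series, on what has been measured and on what is new or still open speak of the compounds shown alone.

The measured compounds:
compound 1, `O=C(/C=C/c1cccc(NC(=O)c2ccccc2Cl)c1)c1nc2ccccc2[nH]1`, with 3690 nM in a functional assay on 143B cells (Homo sapiens) for antiproliferative activity, read by MTT assay, with a stated time of 48 h; on this read-out higher numbers stand for weaker inhibition and lower numbers for stronger inhibition
compound 2, `O=C(/C=C/c1cccc(NC(=O)c2ccccc2Br)c1)c1nc2ccccc2[nH]1`, with 6050 nM in this assay
compound 3, `Cc1cccc(C(=O)Nc2cccc(/C=C/C(=O)c3nc4ccccc4[nH]3)c2)c1`, with 4880 nM in this assay

Compound 1 gives the lowest of the three numbers, but its distance to the other two is small: a 1.6-fold higher number from compound 1 to compound 2 (0.21 log units; within the scatter) and a 1.3-fold higher number from compound 1 to compound 3 (0.12 log units; within the scatter), both within the scatter, so no ordering among the three can be claimed. The same holds for a 1.2-fold lower number from compound 2 to compound 3 (0.09 log units; within the scatter).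

Compound 4, `O=C(/C=C/c1cccc(NS(=O)(=O)c2ccccc2Cl)c1)c1nc2ccccc2[nH]1`, has not yet been measured in this assay. It differs from compound 1 by (2-chlorophenyl)sulfonyl in place of (2-chlorophenyl)carbonyl on a nitrogen on an aromatic ring. Within the data shown here, none of the measured steps touches this part of the molecule: all three swap only the aryl piece attached to the carbonyl, and each leaves the number essentially where it was. Among the measured compounds shown here, the exchange of a carbonyl for a sulfonyl on the ring nitrogen has no measured counterpart here, so any expectation rests on the general observation that changes around this amide have so far moved the numbers little. Compound 4 is therefore expected at 5000 nM, with a range from 1500 nM to 20000 nM, the width reflecting that this change is of a new kind. That estimate corresponds to an expected step of a 1.4-fold higher number from compound 1 to compound 4 (0.13 log units; within the scatter), which would stay within the scatter.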

Compound 4, half-maximal inhibitory concentration: 4790 nM
Compound 4: middle estimate off by 1.0-fold (0.02 log units), on the high side; the range from low to high includes it.
By their numbers in this assay, from the lowest: compounds 1, 4, 3 and 2 (each within the scatter of the next).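

In this assay, among these compounds, the earlier steps changed only the aryl piece on the carbonyl, whereas this change keeps the 2-chlorophenyl and replaces the carbonyl attached to the nitrogen with a sulfonyl. The result is a 1.3-fold higher number from compound 1 to compound 4 (0.11 log units; within the scatter) and, against the other two amides, a 1.0-fold lower number from compound 3 to compound 4 (0.01 log units; within the scatter) and a 1.3-fold lower number from compound 2 to compound 4 (0.10 log units; within the scatter); so at this position the sulfonyl and the carbonyl cannot be told apart in these compounds, even though the entering group counts one more hydrogen-bond acceptor and one more double bond outside aromatic rings. No available measurement explains why the number stays within the scatter across this exchange.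

Only one sulfonyl appears among the compounds shown, so it remains open whether (2-bromophenyl)sulfonyl or (3-methylphenyl)sulfonyl would match their carbonyl counterparts. Among the compounds shown here, also open is what would happen if the aryl piece on the sulfonyl gave way to a simple methyl or a longer alkyl chain, or if it carried an amine or a carboxylic acid, since every group at this position so far is a singly substituted phenyl bearing chlorine, bromine or methyl.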